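Cytotoxicity notes: dichlorophenyl replacement in the amide series

A few compounds are considered here, and "the series" means these few. Any claim that something is new, unique, unknown or untested is made for them only; others in the source may bear on it.

Compound 3 `CC(C)N(Cc1cccc(OCCCCCC(=O)O)c1)C(=O)c1ccc(-c2cccc(F)c2)cc1` is read in an ADME assay on HEK293 cells (Homo sapiens) for cytotoxicity, read by CellTiter-Glo and resazurin assay, with a stated time of 72 h (on this read-out higher numbers stand for an effect only at larger amounts of compound and lower numbers for an effect already at smaller amounts), only as a limit, > 26000 nM. Compound 1 `CC(C)N(Cc1cccc(OCCCCCC(=O)O)c1)C(=O)c1ccc(-c2cccc3ccccc23)cc1` likewise gives only a limit in this assay, > 26000 nM. Compound 2 `CC(C)N(Cc1cccc(OCCCCCC(=O)O)c1)C(=O)c1ccc(-c2ccc3[nH]ccc3c2)cc1` also gives a limit, > 26000 nM. Compound 3 therefore cannot be ranked against the other two beyond the observation that all three sit at the same limit, as summarised by the limit of > 26000 nM in this assay, at which 3 of the 3 values shown sit. The steps a step that the two limits leave unreadable from compound 1 to compound 3 and a step that the two limits leave unreadable from compound 2 to compound 3 end at compound 3 and are the ones bearing on the present change; neither has a readable size, and the same holds for a step that the two limits leave unreadable from compound 1 to compound 2. Compound 4 `CC(C)N(Cc1cccc(OCCCCCC(=O)O)c1)C(=O)c1ccc(-c2ccc(Cl)c(Cl)c2)cc1` differs from compound 3 by 3,4-dichlorophenyl in place of 3-fluorophenyl on an aromatic carbon. Exchanges of the terminal aryl group among compounds 1, 2 and 3 left every read-out at the limit, so no step beyond scatter is expected for compound 4, and the step of a number no higher from compound 3 to compound 4 (the limit leaves the size open) is estimated to amount to no readable change. Compound 4 is therefore expected to return about 26000 nM, within 13000 nM to 60000 nM, most probably again as a limit rather than a number.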

Compound 4, half-maximal effective concentration: > 26000 nM
Compound 4 was reported as a limit; the forecaster's own chance of this, stated with the estimate: 80%; the middle value lies on the limit itself.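

Compound 4 is again reported only as a limit in this assay, so its steps from compounds 1, 2 and 3 cannot be read: the limit of > 26000 nM in this assay, at which 4 of the 4 values shown sit.

The compounds shown leave open at what concentration any of compounds 1, 2, 3 and 4 reaches a half-maximal effect, and whether their terminal aryl groups differ at all.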